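From Methoxyphenyl to Thiophene at the Chain End

This account rests on a few compounds, and the source may have more. Where it says the series, first, only, none or still open, it means among the compounds named here.

In a functional assay on MCF7 cells (Homo sapiens) for cytotoxicity (a lower number here means a stronger inhibitor, a higher number a weaker inhibitor), compound 2 `C=C/C=C\[C@H](C)[C@H](OC(N)=O)[C@@H](C)[C@H](O)[C@@H](C)C/C(C)=C\[C@H](C)[C@@H](O)[C@@H](C)/C=C\CCc1cccc(OC)c1` reads 330 nM and compound 1 `C=C/C=C\[C@H](C)[C@H](OC(N)=O)[C@@H](C)[C@H](O)[C@@H](C)C/C(C)=C\[C@H](C)[C@@H](O)[C@@H](C)/C=C\CCc1ccccc1` reads 480 nM on the same scale, so the two cannot be separated. For the measured compounds named here, the one measured step, a 1.5-fold lower number from compound 1 to compound 2 (0.16 log units; within the scatter) when methoxy replaces hydrogen on an aromatic carbon, lies within the scatter. In compound 3 `C=C/C=C\[C@H](C)[C@H](OC(N)=O)[C@@H](C)[C@H](O)[C@@H](C)C/C(C)=C\[C@H](C)[C@@H](O)[C@@H](C)/C=C\CCc1ccsc1` the change is thiophen-3-yl in place of 3-methoxyphenyl on a saturated chain carbon, two bonds along the chain from a double-bonded chain carbon and the shared core stays untouched. Going by the values given here, no measured compound carries thiophen-3-yl, so the step of a 1.5-fold lower number from compound 1 to compound 2 (0.16 log units; within the scatter) is the only guide and no shift beyond the scatter is expected in this assay here. The estimated change is a 1.3-fold higher number from compound 2 to compound 3 (0.10 log units; within the scatter) and stays inside the scatter. Compound 3 is expected at 420 nM with an estimated range of 170 nM to 1000 nM around it.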

Compound 3, half-maximal inhibitory concentration: 850 nM
For compound 3 the middle estimate is 2.0-fold (0.31 log units) below the measured one, and the stated range covers the measured number.
By their numbers in this assay, from the lowest: compounds 2, 1 and 3 (each within the scatter of the next, the first and the last beyond it).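

In this assay the group at the chain end can shift the number beyond the scatter: thiophen-3-yl in place of 3-methoxyphenyl gives a 2.6-fold higher number from compound 2 to compound 3 (0.41 log units; beyond the scatter) here. Thiophen-3-yl in place of phenyl gives a 1.8-fold higher number from compound 1 to compound 3 (0.25 log units; within the scatter) and so cannot be told apart from phenyl. No available evidence accounts for the larger step. Still open, from the compounds shown here alone, is how this position responds to other end groups such as an amine or a carboxylic acid. Going by these compounds, whether a longer chain before the ring changes the number is also open.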